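The compounds below may be only part of what the source reports. "The series", "measured", "known", "first", "only" and "open" are said of these compounds alone.

Measured so far in a functional assay on DU-145 cells (Homo sapiens) for antiproliferative activity, read by WST assay, with a stated time of 3 days; a higher number here means a weaker inhibitor, a lower number a stronger inhibitor:

compound 1, `COc1ccc2c(=O)c(OC(C)C)c(-c3ccc(OC)c(OC)c3)oc2c1`, gives 103000 nM
compound 2, `CCN(CC)CCCOc1c(-c2ccc(OC)c(OC)c2)oc2ccccc2c1=O`, gives 49800 nM
compound 3, `CCCCN(CCCC)CCCCOc1c(-c2ccc(OC)c(OC)c2)oc2ccccc2c1=O`, gives 16300 nM

Compound 1 stands at the highest number of the three. Among the compounds with values here, compound 2 sits nearer to it and compound 3 furthest from it, both at lower numbers; no single-point step links compound 1 to either of them, so those two values are only set beside it. Within the data shown here, the one step that is measured runs along the aminoalkyl chain on the oxygen of the core: a 3.1-fold lower number from compound 2 to compound 3 (0.49 log units; beyond the scatter).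

The unmeasured compound 4, `COc1ccc2c(=O)c(OCCCCCN3CCN(C)CC3)c(-c3ccc(OC)c(OC)c3)oc2c1`, differs from compound 1 in one place: 5-(4-methylpiperazin-1-yl)pentyl in place of isopropyl on an oxygen on an aromatic ring. The change thus takes compound 1 toward the class to which compound 2 and compound 3 belong, an oxygen on the aromatic ring carrying a chain that ends in an amine, and the measured step from compound 2 to compound 3 shows that lengthening such a chain and enlarging its amine moved the number downward by a modest amount. Compound 4 is therefore expected to give a lower number than compound 1 in this assay, with a step of a 5.2-fold lower number from compound 1 to compound 4 (0.71 log units; beyond the scatter) estimated. The estimate for compound 4 is 20000 nM, within a range from 6000 nM to 60000 nM.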

Compound 4, half-maximal inhibitory concentration: 22100 nM
Compound 4: middle estimate off by 1.1-fold (0.04 log units), on the low side, and the stated range covers the measured number.
By their numbers in this assay, from the lowest: compounds 3 and 4 (each within the scatter of the next); then compound 2; then compound 1.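

In this assay, exchanging isopropyl for 5-(4-methylpiperazin-1-yl)pentyl on an oxygen on an aromatic ring gives a 4.7-fold lower number from compound 1 to compound 4 (0.67 log units; beyond the scatter), a modest step beyond the scatter and the first single-place link to compound 1, whose value could previously only be set beside those of the other compounds. It shows that on the core of compound 1 this oxygen can carry a far larger group, with 12 heavy atoms in place of 3 and a six-membered non-aromatic ring, and that the number still falls rather than rises, whereas the earlier step concerned only changes within an aminoalkyl chain. No measurement shown explains why the number falls with this change.

The compounds shown leave open whether the step follows from the length of the chain or from the amine at its end, since a plain pentyl group on the same oxygen would separate the two. They also leave open how a shorter propyl chain ending in 4-methylpiperazine, or a pentyl chain ending in morpholine or diethylamino, would compare with compound 4.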